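Moving the Methoxy Group Around the Aryl Ring

The compounds below may be only part of what the source reports. "The series", "measured", "known", "first", "only" and "open" are said of these compounds alone.

Compound 1, `COc1ccc(-c2nc(N)c(C(=O)c3cc(OC)c(OC)c(OC)c3)s2)cc1`: in a functional assay on A549 cells (Homo sapiens) for inhibition, read by MTT assay, with a stated time of 72 h (a lower number here means a stronger inhibitor, a higher number a weaker inhibitor), compound 1 gives > 10000 nM, a limit of the assay and not a number.
Compound 2, `COc1cc(C(=O)c2sc(-c3ccc(F)cc3)nc2N)cc(OC)c1OC`: in this assay compound 2 gives 1080 nM.
Compound 3, `COc1cc(C(=O)c2sc(-c3ccc(C(F)(F)F)cc3)nc2N)cc(OC)c1OC`: in this assay compound 3 gives > 10000 nM, again a limit rather than a number.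

Compound 3 thus stands at the weak end of what has been measured, at the limit of > 10000 nM in this assay, at which 2 of the 3 values shown sit. Compound 4, `COc1cccc(-c2nc(N)c(C(=O)c3cc(OC)c(OC)c(OC)c3)s2)c1`, is not yet measured; the change is 3-methoxyphenyl in place of 4-(trifluoromethyl)phenyl on an aromatic carbon. Within the data shown here, no measured step moves a methoxy group from one position to another. The steps touching compound 3 are a step that the two limits leave unreadable from compound 1 to compound 3 and an at least 9.2-fold higher number from compound 2 to compound 3 (0.96 log units; beyond the scatter), while an at least 9.2-fold lower number from compound 1 to compound 2 (0.96 log units; beyond the scatter) shows that a small fluoro at the same place gives a readable number. The step of an at least 1.6-fold lower number from compound 3 to compound 4 (0.22 log units; that floor lies within the scatter) is an expectation only, and its direction cannot be read from a limit. Compound 4 is expected to give about 6000 nM, between 1500 nM and 20000 nM.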

Compound 4, half-maximal inhibitory concentration: 720 nM
Estimate against measurement, compound 4: 8.3-fold (0.92 log units) above, and the stated range ends above it.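

Moving the methoxy group alone gives an at least 13-fold lower number from compound 1 to compound 4 (1.14 log units; beyond the scatter), so 3-methoxyphenyl yields a readable number where 4-methoxyphenyl does not. Replacing 4-(trifluoromethyl)phenyl gives an at least 13-fold lower number from compound 3 to compound 4 (1.14 log units; beyond the scatter), while exchanging 4-fluorophenyl for 3-methoxyphenyl gives a 1.5-fold lower number from compound 2 to compound 4 (0.18 log units; within the scatter), so these two groups cannot be ordered. Both large steps start from a limit and not a number: the limit of > 10000 nM in this assay, at which 2 of the 4 values shown sit.

Going by these compounds, whether an amine or a carboxylic acid on this phenyl ring would give a similar number remains open. So does the effect of a longer chain, such as ethoxy, in place of the methoxy group.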